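Thiosemicarbazone series: chloro replaces fluoro on the aryl

The source may hold more compounds than are shown below. What is called first, only, known or untested is meant among the compounds shown, and "the series" means these compounds.

compound 1 `CC1=CC[C@H](C(C)(C)NC(=S)N/N=C/c2ccc(O)cc2)CC1`: > 100000 nM
compound 2 `CC1=CC[C@H](C(C)(C)NC(=S)N/N=C/c2ccc(F)cc2)CC1`: > 100000 nM

In a functional assay on HT-29 cells (Homo sapiens) for inhibition, read by sulforhodamine B assay, with a stated time of 48 h (on this read-out lower numbers stand for stronger inhibition of growth and higher numbers for weaker inhibition of growth), compound 1 gives only a limit, > 100000 nM. Compound 2 likewise gives only a limit in this assay, > 100000 nM. The step that the two limits leave unreadable from compound 1 to compound 2 is thus not readable. For the measured compounds named here, the numbers so far amount to the limit of > 100000 nM in this assay, at which 2 of the 2 values shown sit. Compound 2 therefore stands at the limit, with no finite value to rank it. Compound 3 `CC1=CC[C@H](C(C)(C)NC(=S)N/N=C/c2cccc(Cl)c2)CC1` differs from compound 2 by 3-chlorophenyl in place of 4-fluorophenyl on a carbon with a double bond to nitrogen. Going by the values given here, no measured step bears on this change, and the one step in hand is unreadable. Compound 3 is expected to sit at a limit again, estimated at 100000 nM within 30000 nM to 300000 nM. For compound 3 the step this estimate means is expected to be a number no higher from compound 2 to compound 3 (the limit leaves the size open), none beyond the scatter.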

Compound 3, concentration for 50% growth inhibition: 7900 nM
Beside the measured number, compound 3's estimate is 13-fold (1.10 log units) above it, outside the stated range (below it).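

In this assay, the aryl group on a carbon with a double bond to nitrogen proves able to move the read-out: 3-chlorophenyl in place of 4-fluorophenyl gives an at least 12-fold lower number from compound 2 to compound 3 (1.10 log units; beyond the scatter), and 3-chlorophenyl in place of 4-hydroxyphenyl gives an at least 12-fold lower number from compound 1 to compound 3 (1.10 log units; beyond the scatter). Compound 3 alone has a finite value, while the other two remain limits: the limit of > 100000 nM in this assay, at which 2 of the 3 values shown sit.

The change from 4-fluorophenyl to 3-chlorophenyl alters both the halogen and its ring position, so these two contributions remain unseparated. Still open, on these data alone, are 4-chlorophenyl, 3-fluorophenyl and a 3-aminophenyl group at this place.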